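From Pyridin-4-yl to 1-Methyl-1H-imidazol-2-yl on the Amine

A few compounds are considered here, and "the series" means these few. Any claim that something is new, unique, unknown or untested is made for them only; others in the source may bear on it.

Of the compounds shown here, three sharing one core have been tested in an assay on isolated protein for activation of cGMP-dependent protein kinase 1 (Homo sapiens), read by ADP-Glo, with stated times of 120 min and 40 min; on this read-out higher numbers stand for an effect only at larger amounts of compound and lower numbers for an effect already at smaller amounts. Compound 1 `Clc1cc(Cl)cc(CO[C@H]2CCCN(Cc3ncco3)[C@H]2c2ccccc2)c1` carries a 1,3-oxazol-2-yl group on the saturated chain carbon bound to the amine nitrogen in the ring. In this assay compound 1 reaches only the limit of > 200000 nM, not a number. Compound 2 `COc1cc(C(=O)O)ccc1CN1CCC[C@H](OCc2cc(Cl)cc(Cl)c2)[C@@H]1c1ccccc1` carries a 4-carboxy-2-methoxyphenyl group in that place and gives 62000 nM in this assay. Compound 3 `Clc1cc(Cl)cc(CO[C@H]2CCCN(Cc3ccncc3)[C@H]2c2ccccc2)c1` carries pyridin-4-yl there. For compound 3 this assay again reports only the limit of > 200000 nM. So compound 3 stands at the weak end of the set, as the limit of > 200000 nM in this assay, at which 2 of the 3 values shown sit, shows. The step of an at least 3.2-fold higher number from compound 2 to compound 3 (0.50 log units; beyond the scatter) is readable in direction, whereas the step that the two limits leave unreadable from compound 1 to compound 3 is not. Compound 4 `Cn1ccnc1CN1CCC[C@H](OCc2cc(Cl)cc(Cl)c2)[C@@H]1c1ccccc1` differs from compound 3 by 1-methyl-1H-imidazol-2-yl in place of pyridin-4-yl on a saturated chain carbon bound to an amine nitrogen in a ring. Within the data shown here, the steps that bear on this change are the two that exchange one small aromatic ring for another at this place: a step that the two limits leave unreadable from compound 1 to compound 3 leaves both ends at the limit, and an at least 3.2-fold higher number from compound 2 to compound 3 (0.50 log units; beyond the scatter) shows that only the 4-carboxy-2-methoxyphenyl group yields a readable number. Compound 4 is therefore expected to remain at the limit, estimated at 300000 nM with a range from 100000 nM to 1000000 nM. The expected step that the limit leaves unreadable from compound 3 to compound 4 is thus none beyond the scatter.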

Compound 4, half-maximal effective concentration: 165000 nM
Estimate against measurement, compound 4: 1.8-fold (0.26 log units) above; low and high end bracket the measured number.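

The 1-methyl-1H-imidazol-2-yl group gives the first actual number from a small aromatic ring at this place, on a saturated chain carbon bound to an amine nitrogen in a ring: in this assay, compound 4 has a measured value, whereas compound 1 and compound 3 remain limits and not numbers: the limit of > 200000 nM in this assay, at which 2 of the 4 values shown sit.

That does not establish that this ring outperforms the other two, as an at least 1.2-fold lower number from compound 3 to compound 4 (0.08 log units; that floor lies within the scatter) and an at least 1.2-fold lower number from compound 1 to compound 4 (0.08 log units; that floor lies within the scatter) give only floors for the change. The clearer comparison is a 2.7-fold higher number from compound 2 to compound 4 (0.43 log units; beyond the scatter), which leaves compound 2 with the lower number while showing that a small ring with no carboxylic acid can give a measurable value.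

The compounds shown leave open how far compound 1 and compound 3 truly lie from compound 4, since their limits hide the real size of those steps. They also leave open which part of the 4-carboxy-2-methoxyphenyl group matters, which a phenyl ring carrying only the carboxylic acid or only the methoxy group could help to separate.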